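From 3-Fluorobenzyl to 4-Chlorobenzyl on a Shared Core

A few compounds are considered here, and "the series" means these few. Any claim that something is new, unique, unknown or untested is made for them only; others in the source may bear on it.

Measured so far in an ADME assay on HEK-293T cells (Homo sapiens) for inhibition, read by CCK-8 assay, with a stated time of 48 h, tested at 20 uM; on this read-out higher numbers stand for more inhibition of growth at the one concentration tested and lower numbers for less inhibition of growth
compound 1 `COc1ccc(S(=O)(=O)Oc2ccccc2/C=C(\C#N)C(=O)Nc2nnc(-c3cccs3)s2)cc1` gives 40%
compound 2 `COc1ccc(S(=O)(=O)Oc2ccccc2/C=C(\C#N)C(=O)Nc2nnc(Cc3ccc(F)cc3)s2)cc1` gives 20%
compound 3 `COc1ccc(S(=O)(=O)Oc2ccccc2/C=C(\C#N)C(=O)Nc2nnc(Cc3cccc(F)c3)s2)cc1` gives 29%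

Compound 3 stands apart from compound 1 but cannot be told apart from compound 2. Putting 3-fluorobenzyl in place of thiophen-2-yl gives a number 11 percentage points lower from compound 1 to compound 3 (beyond the scatter) and putting 4-fluorobenzyl there gives a number 20 percentage points lower from compound 1 to compound 2 (beyond the scatter) as the comparable result. Both of those steps replace a whole group, so they say little about the smaller change ahead.

Compound 4 `COc1ccc(S(=O)(=O)Oc2ccccc2/C=C(\C#N)C(=O)Nc2nnc(Cc3ccc(Cl)cc3)s2)cc1` carries 4-chlorophenyl in place of 3-fluorophenyl on a saturated chain carbon bound to an aromatic carbon. The closest guide is the exchange of 4-fluorophenyl for 3-fluorophenyl, which gives a number 9 percentage points higher from compound 2 to compound 3 (within the scatter) as its result. For the measured compounds named here, no chlorine-bearing compound has been measured yet, so the guess stays wide. The expected change is a number 5 percentage points lower from compound 3 to compound 4 (within the scatter) and no step beyond the scatter is expected. For compound 4 the expected value is 24% with 10% to 40% as the estimated range of the result.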

Compound 4, percent growth inhibition at one concentration: 26%
The estimate for compound 4 lay 2 percentage points below the measured number, and the stated range covers the measured number.
By their numbers in this assay, from the lowest: compounds 2, 4 and 3 (each within the scatter of the next); then compound 1.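

In this assay, the first chlorine-bearing compound does not separate from its fluorine-bearing relatives: 4-chlorophenyl in place of 3-fluorophenyl gives a number 3 percentage points lower from compound 3 to compound 4 (within the scatter), and chloro in place of fluoro on an aromatic carbon gives a number 6 percentage points higher from compound 2 to compound 4 (within the scatter). Compound 2, compound 3 and compound 4 therefore cannot be told apart, whichever of these halogen changes is made, while 4-chlorobenzyl in place of thiophen-2-yl gives a number 14 percentage points lower from compound 1 to compound 4 (beyond the scatter), so all three benzyl compounds now stand apart from compound 1. Nothing available explains these results.

As far as these compounds go, it remains open whether a benzyl ring carrying an amine or a carboxylic acid would stay with these three compounds or come closer to compound 1. From the compounds shown here alone, the effect of a longer chain between the ring and the shared core also remains open.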